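Swapping the amide's aryl group in a pyrazole series

This account rests on a few compounds, and the source may have more. Where it says the series, first, only, none or still open, it means among the compounds named here.

Measured so far:
compound 1, `COc1cc(Cl)cc(-c2nn(-c3cccc(NC(=O)c4ccc(Cl)c(Cl)c4)c3)cc2-c2ccncc2)c1`: 58.4%
compound 2, `O=C(Nc1cccc(-n2cc(-c3ccncc3)c(-c3cc(O)cc(Cl)c3)n2)c1)Nc1ccc(Cl)c(Cl)c1`: -14.8%
compound 3, `COc1cc(Cl)cc(-c2nn(-c3cccc(NC(=O)Nc4cc(C(F)(F)F)cc(C(F)(F)F)c4)c3)cc2-c2ccncc2)c1`: -2.46%

In a functional assay on OVCAR-8 cells (Homo sapiens) for inhibition, read by sulforhodamine B assay, with a stated time of 48 h, tested at 10 uM (a higher number here means a weaker effect of the compound at the concentration tested, a lower number a stronger effect), compound 1 gives 58.4%, the highest of the three numbers, meaning the weakest effect at the tested concentration; compound 2 and compound 3 both sit far lower, beyond the scatter.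

Compound 4, `COc1cc(Cl)cc(-c2nn(-c3cccc(NC(=O)c4cccc(C(F)(F)F)c4)c3)cc2-c2ccncc2)c1`, keeps the core of compound 1 and changes only the amide end: 3-(trifluoromethyl)phenyl in place of 3,4-dichlorophenyl on a carbonyl carbon. Going by the values given here, no measured pair shows this particular change, so its size is unknown. Compound 4 is expected to stay close to compound 1, with a step of a number 8.4 percentage points lower from compound 1 to compound 4 (within the scatter) that may well fall within the scatter, perhaps leaning slightly toward a stronger effect. The estimate for compound 4 in this assay is 50%, within a range of 20% to 85%.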

Compound 4, a percentage reported as activity, at one concentration (the size of the read-out at that concentration, not a potency): 42%
Beside the measured number, compound 4's estimate is 8 percentage points above it; the range from low to high includes it.
By their numbers in this assay, from the lowest: compound 2; then compound 3; then compound 4; then compound 1.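

In this assay, the aryl group on the carbonyl carbon affects the read-out. With the core of compound 1 held fixed, 3-(trifluoromethyl)phenyl in place of 3,4-dichlorophenyl gives a modest but real step (a number 16.4 percentage points lower from compound 1 to compound 4 (beyond the scatter)). Going by these compounds alone, this is the first comparison here that isolates a single change at this position, and no available evidence explains the shift.

Still open, on these data alone, is how an unsubstituted phenyl, or a phenyl carrying an amine or a carboxylic acid, would behave on the same carbonyl carbon. Those groups would show whether the number can move further in either direction.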